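The compounds below may be only part of what the source reports. "The series", "measured", "known", "first", "only" and "open" are said of these compounds alone.

Among the compounds with values here, the three compounds measured so far share one core and differ only in the group carried on an amine nitrogen in a ring. In an assay on membranes from brain for displacement of a labelled ligand from Sigma non-opioid intracellular receptor 1 (Cavia porcellus), read by scintillation counting, with a stated time of 120 min (on this read-out lower numbers stand for stronger inhibition and higher numbers for weaker inhibition), compound 1 `CCCCN1CCN(CCC(=O)Nc2nc3c(C)cccc3s2)CC1` gives 204 nM, compound 2 `Cc1cccc2sc(NC(=O)CCN3CCN(CCCN(C)C)CC3)nc12` gives 570 nM, and compound 3 `Cc1cccc2sc(NC(=O)CCN3CCN(CC4CCCCC4)CC3)nc12` gives 35 nM. Compound 3 stands lowest of the three: the step of a 5.8-fold lower number from compound 1 to compound 3 (0.77 log units; beyond the scatter) and the step of a 16-fold lower number from compound 2 to compound 3 (1.21 log units; beyond the scatter) both lie beyond the scatter, while the step of a 2.8-fold higher number from compound 1 to compound 2 (0.45 log units; beyond the scatter) is the smallest of the set. Compound 4 `Cc1ccccc1N1CCN(CCC(=O)Nc2nc3c(C)cccc3s2)CC1` differs from compound 3 by 2-methylphenyl in place of cyclohexylmethyl on an amine nitrogen in a ring. Within the data shown here, no measured step exchanges a saturated ring for an aromatic one, so the guidance is indirect: the two steps that end at compound 3 show that the cyclohexyl-bearing group gave the lowest number of the set, and compound 4 gives that ring up. A moderate rise in this assay is therefore expected, a 3.4-fold higher number from compound 3 to compound 4 (0.54 log units; beyond the scatter), with the direction held loosely. The estimate for compound 4 is 120 nM, within 30 nM to 500 nM.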

Compound 4, inhibition constant: 1000 nM
Beside the measured number, compound 4's estimate is 8.3-fold (0.92 log units) below it; the whole stated range lies below it.
By their numbers in this assay, from the lowest: compound 3; then compound 1; then compounds 2 and 4 (each within the scatter of the next).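

At the amine nitrogen in a ring, cyclohexylmethyl and 2-methylphenyl match in heavy atoms and in hydrogen-bond donors and acceptors, yet in this assay this change gives the largest step of the set (a 29-fold higher number from compound 3 to compound 4 (1.46 log units; beyond the scatter)), so those counts alone do not settle the number at this position. The aromatic group also gives a number beyond the scatter from that of the butyl group (a 4.9-fold higher number from compound 1 to compound 4 (0.69 log units; beyond the scatter)), while it cannot be told apart from 3-(dimethylamino)propyl (a 1.8-fold higher number from compound 2 to compound 4 (0.24 log units; within the scatter)). Nothing measured here explains the size of this step.

As far as these compounds go, it remains open whether the result follows from the aromatic ring itself, the methyl group on it, or the missing chain carbon. Plain phenyl, benzyl and cyclohexyl directly on the ring nitrogen would separate these three.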